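Urea analogue with dichlorophenyl: expected growth inhibition

The source may report more compounds than this note shows. Statements on the series, on what has been measured and on what is new or still open speak of the compounds shown alone.

Of the compounds shown here, three sharing one core have been measured in a functional assay on SK-BR-3 cells (Homo sapiens) for inhibition, read by MTT assay, with a stated time of 2 days, tested at 100 uM; a higher number here means more inhibition of growth at the concentration tested, a lower number less inhibition of growth. Compound 1 `CNC(=O)c1cc(Oc2ccc3nc(NC(=O)c4ccc(Cl)cc4Cl)sc3c2)ccn1` gives 81%, compound 2 `CNC(=O)c1cc(Oc2ccc3nc(NC(=O)c4cccc(F)n4)sc3c2)ccn1` gives 89.4%, and compound 3 `CNC(=O)c1cc(Oc2ccc3nc(NC(=O)Nc4ccc(Br)cc4)sc3c2)ccn1` gives 69.2%, the lowest of the three: the step of a number 11.8 percentage points lower from compound 1 to compound 3 (beyond the scatter) and the step of a number 20.2 percentage points lower from compound 2 to compound 3 (beyond the scatter) both run downward beyond the scatter. Compound 4 `CNC(=O)c1cc(Oc2ccc3nc(NC(=O)Nc4ccc(Cl)cc4Cl)sc3c2)ccn1` differs from compound 3 only in one place: 2,4-dichlorophenyl in place of 4-bromophenyl on an amide-type nitrogen. Among the measured compounds shown here, no measured step isolates this swap alone. The closest guide is compound 1, which carries the same 2,4-dichlorophenyl on a carbonyl carbon, and the step of a number 11.8 percentage points lower from compound 1 to compound 3 (beyond the scatter) combines that aryl change with the change of linker. Because of a number 11.8 percentage points lower from compound 1 to compound 3 (beyond the scatter) compound 4 is expected to sit between compound 3 and compound 1, at 74% with a range from 60% to 88%. The estimated step is a number 4.8 percentage points higher from compound 3 to compound 4 (within the scatter), within the scatter.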

Compound 4, percent growth inhibition at one concentration: 91.7%
Beside the measured number, compound 4's estimate is 17.7 percentage points below it, outside the stated range (above it).
By their numbers in this assay, from the lowest: compound 3; then compounds 1, 2 and 4 (each within the scatter of the next, the first and the last beyond it).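

In this assay, the aryl group on this amide-type nitrogen clearly counts: 2,4-dichlorophenyl in place of 4-bromophenyl gives a number 22.5 percentage points higher from compound 3 to compound 4 (beyond the scatter), so the urea-type linker of compound 3 does not by itself set its low number. With 2,4-dichlorophenyl kept, placing an amino link on the carbonyl carbon gives a number 10.7 percentage points higher from compound 1 to compound 4 (beyond the scatter), while the swap from 6-fluoropyridin-2-yl gives a number 2.3 percentage points higher from compound 2 to compound 4 (within the scatter), a step within the scatter. No measurement here explains these steps.

As far as these compounds go, it remains open whether the step from compound 3 follows the change from bromine to chlorine or the second chlorine. A 4-chlorophenyl group on the same nitrogen would separate the two.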